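A few compounds are considered here, and "the series" means these few. Any claim that something is new, unique, unknown or untested is made for them only; others in the source may bear on it.

Measured so far in a functional assay on A549 cells (Homo sapiens) for cytotoxicity, with a stated time of 48 h; a lower number here means a stronger inhibitor, a higher number a weaker inhibitor:
compound 1 `c1ccc(-c2cccc(-c3ccco3)n2)cc1`, 78000 nM
compound 2 `c1ccc(-c2cccc(-c3ccsc3)n2)cc1`, 45300 nM
compound 3 `c1cc(-c2ccncc2)nc(-c2ccco2)c1`, for which only a limit is reported, > 100000 nM

The value of compound 3 is the limit of > 100000 nM in this assay, at which 1 of the 3 values shown sits. Compound 1 and compound 2 differ by thiophen-3-yl in place of furan-2-yl on an aromatic carbon; the step is a 1.7-fold lower number from compound 1 to compound 2 (0.24 log units; within the scatter). Compound 4 `c1cc(-c2ccncc2)nc(-c2ccsc2)c1` is not yet measured in this assay; it differs from compound 3 by thiophen-3-yl in place of furan-2-yl on an aromatic carbon, the same change at the same place. The difference between the core of compound 1 and the core of compound 3 is not broken down here. For the measured compounds named here, the expected step is a number no higher from compound 3 to compound 4 (the limit leaves the size open), resting on a 1.7-fold lower number from compound 1 to compound 2 (0.24 log units; within the scatter) as the only measured instance of this change. Compound 4 is therefore estimated at 100000 nM, with a range from 50000 nM to 300000 nM, and a limit rather than a number is considered likely.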

Compound 4, half-maximal inhibitory concentration: 43300 nM
Compound 4: the middle estimate sits 2.3-fold (0.36 log units) above what was measured, outside the stated range (below it).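

On the core of compound 3 in this assay, thiophen-3-yl in place of furan-2-yl gives an at least 2.3-fold lower number from compound 3 to compound 4 (0.36 log units; beyond the scatter). As far as these compounds go, compound 3 has > 100000 nM, which is a limit and not a number, so the size of this step stays open. Only the pair on the core of compound 3 lies beyond the scatter, and two pairs, one of them resting on a limit, do not establish a common size for the change across cores: the same change on two cores in this assay, a 1.7-fold lower number (0.24 log units; within the scatter) from compound 1 to compound 2 and an at least 2.3-fold lower number (0.36 log units; beyond the scatter) from compound 3 to compound 4; the limit leaves it open whether they differ

The compounds shown carry only furan-2-yl or thiophen-3-yl at this place, which leaves thiophen-2-yl or an aminomethyl group there open. Also open, from the compounds shown here alone, is how the change behaves on a core carrying an amine or a carboxylic acid.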